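Removing One Hydroxy from Compound 3 in a Flat Series

This account rests on a few compounds, and the source may have more. Where it says the series, first, only, none or still open, it means among the compounds named here.

Values in a functional assay on A549 cells (Homo sapiens) for cytotoxicity, read by MTT assay, with a stated time of 72 h; on this read-out higher numbers stand for weaker inhibition and lower numbers for stronger inhibition:
- Compound 1 `COc1cc2ncnc(Nc3ccc(F)c(Cl)c3)c2cc1NC(=O)N/N=C/c1ccc([N+](=O)[O-])cc1`: 35100 nM
- Compound 2 `COc1cc2ncnc(Nc3ccc(F)c(Cl)c3)c2cc1NC(=O)N/N=C/c1cccc(Cl)c1Cl`: 35300 nM
- Compound 3 `COc1cc2ncnc(Nc3ccc(F)c(Cl)c3)c2cc1NC(=O)N/N=C/c1ccc(O)cc1O`: 31400 nM

Compound 3 stands level with the other two compounds, since a 1.1-fold lower number from compound 1 to compound 3 (0.05 log units; within the scatter) and a 1.1-fold lower number from compound 2 to compound 3 (0.05 log units; within the scatter) both lie within the scatter. The next compound is compound 4 `COc1cc2ncnc(Nc3ccc(F)c(Cl)c3)c2cc1NC(=O)N/N=C/c1ccc(O)cc1`, not yet measured in this assay. It differs from compound 3 by hydrogen in place of hydroxy on an aromatic carbon, which is hydrogen in place of hydroxy on an aromatic carbon, turning 2,4-dihydroxyphenyl into 4-hydroxyphenyl.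

Within the data shown here, no measured step removes a single hydroxy, so the evidence is indirect. It comes from exchanges of the whole aryl group: a 1.1-fold lower number from compound 1 to compound 3 (0.05 log units; within the scatter), a 1.1-fold lower number from compound 2 to compound 3 (0.05 log units; within the scatter) and a 1.0-fold higher number from compound 1 to compound 2 (0.00 log units; within the scatter). None of these exchanges moved the number beyond the scatter, so no step beyond the scatter is expected here, in either direction. The expected change is a 1.0-fold higher number from compound 3 to compound 4 (0.01 log units; within the scatter). For compound 4 the estimated value in this assay is 32000 nM, with an expected range from 17000 nM to 60000 nM.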

Compound 4, half-maximal inhibitory concentration: 7610 nM
The estimate for compound 4 lay 4.2-fold (0.62 log units) above the measured number, and the stated range ends above it.
By their numbers in this assay, from the lowest: compound 4; then compounds 3, 1 and 2 (each within the scatter of the next).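

In this assay, among these compounds, the hydroxy ortho to a large group proved to be the one change here that moves the number: its removal gives a 4.1-fold lower number from compound 3 to compound 4 (0.62 log units; beyond the scatter), whereas no earlier exchange of the aryl group left the scatter. Compound 4 also separates from the other two compounds, with a 4.6-fold lower number from compound 2 to compound 4 (0.67 log units; beyond the scatter) and a 4.6-fold lower number from compound 1 to compound 4 (0.66 log units; beyond the scatter), which makes it the most potent of the four and shows that this aryl position is not as flat as compounds 1, 2 and 3 suggested. No measurement shown here bears on why the number falls.

The compounds shown leave open whether the remaining hydroxy of compound 4 contributes to its lower number. Replacing that hydroxy with a methoxy or an amine would test this directly.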